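Phenyl for methyl on the naphthoquinone side chain

The compounds below may be only part of what the source reports. "The series", "measured", "known", "first", "only" and "open" are said of these compounds alone.

Measured compounds: compound 1 `CC(C)=CC(O)C1=CC(=O)c2ccccc2C1=O` gives 5200 nM; compound 2 `CC(O)C1=CC(=O)c2ccccc2C1=O` gives 6400 nM; compound 3 `O=C1C=C([C@@H](O)c2ccccc2)C(=O)c2ccccc21` gives 3800 nM, all in a functional assay on WHCO1 cells (Homo sapiens) for cytotoxicity, read by MTT assay, with a stated time of 24 h; on this read-out lower numbers stand for stronger inhibition and higher numbers for weaker inhibition.

Compound 2 holds the highest number of the three, but its gaps to compound 1 and compound 3 both fall within the scatter. Compound 4 `O=C1C=C(C(O)c2ccccc2)C(=O)c2ccccc21` differs from compound 2 by phenyl in place of methyl on a saturated chain carbon bound to a double-bonded ring carbon and an oxygen on a saturated carbon. For the measured compounds named here, only one measured step touches this position, a 1.2-fold higher number from compound 1 to compound 2 (0.09 log units; within the scatter), and it stayed within the scatter. Compound 3 carries the same phenyl group and gives a number near compound 2. Compound 4 is therefore expected to show no step beyond the scatter, a 1.6-fold lower number from compound 2 to compound 4 (0.20 log units; within the scatter). The estimate for compound 4 is 4000 nM, with a range from 2000 nM to 8000 nM.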

Compound 4, half-maximal inhibitory concentration: 3900 nM
Estimate against measurement, compound 4: 1.0-fold (0.01 log units) above; measured number inside the range.
By their numbers in this assay, from the lowest: compounds 3, 4, 1 and 2 (each within the scatter of the next).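

In this assay, phenyl at this saturated chain carbon stays within the scatter of methyl, a 1.6-fold lower number from compound 2 to compound 4 (0.22 log units; within the scatter), and of 2-methylprop-1-en-1-yl, a 1.3-fold lower number from compound 1 to compound 4 (0.12 log units; within the scatter). All three groups at this carbon, including one with a six-membered aromatic ring, therefore give numbers that cannot be told apart here. Drawing the stereocentre as S or leaving it undefined also stays within the scatter, a 1.0-fold higher number from compound 3 to compound 4 (0.01 log units; within the scatter), and this comparison rests on one point: the fact that one of compounds 3 and 4 is drawn with a defined configuration and the other without, at the place where they differ

Going by these compounds, whether an amine, a carboxylic acid or a longer chain at this carbon would move the number beyond the scatter stays open. So does the reading for the R configuration at this carbon.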